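The source may report more compounds than this note shows. Statements on the series, on what has been measured and on what is new or still open speak of the compounds shown alone.

Measured so far in an assay on THP-1 cells for displacement of a labelled ligand from C-C chemokine receptor type 1 (Homo sapiens); a higher number here means a weaker inhibitor, a lower number a stronger inhibitor: compound 1 `Cc1cccc(CCC(=O)N[C@@H](C(=O)N2CCC(c3ccc(Cl)cc3)CC2)C(C)C)c1` gives 22 nM. Compound 2 `CC(C)[C@@H](NC(=O)c1cc2ccccc2s1)C(=O)N1CCC(c2ccc(Cl)cc2)CC1` gives 58 nM.

Among the compounds with values here, compound 2 has the higher of the two numbers, so it is the weaker inhibitor; its only neighbour is compound 1, reached by a 2.6-fold higher number from compound 1 to compound 2 (0.42 log units; beyond the scatter). Compound 3 `Cc1ccccc1CCC(=O)N[C@@H](C(=O)N1CCC(c2ccc(Cl)cc2)CC1)C(C)C` carries 2-(2-methylphenyl)ethyl in place of 1-benzothiophen-2-yl on a carbonyl carbon. This change largely reverses that single measured step, the only one that bears on it, except that the new group is 2-(2-methylphenyl)ethyl where compound 1 has 2-(3-methylphenyl)ethyl. A modest step toward lower numbers, near the size of the measured one, is therefore expected: a 1.9-fold lower number from compound 2 to compound 3 (0.29 log units; within the scatter). Compound 3 is accordingly estimated at 30 nM, with a range from 12 nM to 80 nM.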

Compound 3, half-maximal inhibitory concentration: 19 nM
Beside the measured number, compound 3's estimate is 1.6-fold (0.20 log units) above it; low and high end bracket the measured number.
By their numbers in this assay, from the lowest: compounds 3 and 1 (each within the scatter of the next); then compound 2.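

In this assay, a second methylphenyl chain on the carbonyl carbon also outperforms 1-benzothiophen-2-yl: 2-(2-methylphenyl)ethyl gives a 3.1-fold lower number from compound 2 to compound 3 (0.48 log units; beyond the scatter) and so matches the direction seen with 2-(3-methylphenyl)ethyl. Putting 2-methylphenyl in place of 3-methylphenyl gives a 1.2-fold lower number from compound 1 to compound 3 (0.06 log units; within the scatter) and the two compounds cannot be told apart, so either methylphenyl serves equally here. Nothing available explains these results. Still open, on these data alone, is how a plain phenyl, a 2-chlorophenyl or a longer chain would fare at this place.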